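A few compounds are considered here, and "the series" means these few. Any claim that something is new, unique, unknown or untested is made for them only; others in the source may bear on it.

Measured compounds in this series:

compound 1 `C=C1[C@@H](OC(C)=O)C[C@@H]2[C@](C)(COC=O)[C@H](OC(C)=O)CC[C@@]2(C)[C@@H]1C[C@@H](Nc1cccc(F)c1)C1=CCOC1=O`: 14100 nM
compound 2 `C=C1CC[C@@H]2[C@](C)(CO[Si](C)(C)C(C)(C)C)[C@H](OC(C)=O)CC[C@@]2(C)[C@@H]1C/C=C1/C(=O)OC[C@H]1OC(C)=O`: 4840 nM
compound 3 `C=C1[C@@H](OC(C)=O)C[C@@H]2[C@](C)(CO[Si](C)(C)C(C)(C)C)[C@H](OC(C)=O)CC[C@@]2(C)[C@@H]1C[C@@H](Nc1cccc(F)c1)C1=CCOC1=O`: 3820 nM

In a functional assay on MCF7 cells (Homo sapiens) for cytotoxicity, read by sulforhodamine B assay (a higher number here means a weaker inhibitor, a lower number a stronger inhibitor), compound 1 stands highest of the three numbers, so the weakest of the measured set. Compound 3 gives 3820 nM and compound 2 gives 4840 nM, both beyond the scatter from compound 1. Within the data shown here, the only single-place step measured so far is a 3.7-fold lower number from compound 1 to compound 3 (0.57 log units; beyond the scatter), a swap on an oxygen on a saturated carbon; it leaves the amine nitrogen and its aryl group untouched.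

Compound 4 `C=C1[C@@H](OC(C)=O)C[C@@H]2[C@](C)(COC=O)[C@H](OC(C)=O)CC[C@@]2(C)[C@@H]1C[C@@H](Nc1ccc(C(=O)O)cc1)C1=CCOC1=O` differs from compound 1 by 4-carboxyphenyl in place of 3-fluorophenyl on an amine nitrogen. Among the measured compounds shown here, no measured pair varies the group on the amine nitrogen, so no step in hand bears directly on this change; the one step recorded concerns a different site. On these data alone, with nothing to anchor a direction, the working expectation is no change beyond the scatter in this assay, with a wide range on either side because the relevant site is unexplored. Compound 4 is estimated at 14000 nM (range 4000 nM to 50000 nM), which means an expected step of a 1.0-fold lower number from compound 1 to compound 4 (0.00 log units; within the scatter).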

Compound 4, half-maximal inhibitory concentration: 41700 nM
Estimate against measurement, compound 4: 3.0-fold (0.47 log units) below, and the stated range covers the measured number.
By their numbers in this assay, from the lowest: compounds 3 and 2 (each within the scatter of the next); then compound 1; then compound 4.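

In this assay the group on the amine nitrogen proves able to move the number: 4-carboxyphenyl in place of 3-fluorophenyl gives a weaker inhibitor (a 3.0-fold higher number from compound 1 to compound 4 (0.47 log units; beyond the scatter)). Among these compounds, this is the first measured change at this position, as the earlier step concerned a swap on an oxygen on a saturated carbon and left the amine nitrogen and its aryl group untouched. No data on hand account for the step.

A single pair cannot separate the arrival of the carboxylic acid from the departure of the fluorine, and a plain phenyl or a methyl ester on the amine nitrogen would bear on that question. Also open, on these data alone, is whether the same exchange would give a similar step on compound 3, which carries a different group on that oxygen.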